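Lengthening the chain of compound 2 by butyl

A few compounds are considered here, and "the series" means these few. Any claim that something is new, unique, unknown or untested is made for them only; others in the source may bear on it.

Of the compounds shown here, three have been read in a functional assay on HCT-116 cells (Homo sapiens) for antiproliferative activity, read by MTT assay, with a stated time of 48 h; on this read-out lower numbers stand for stronger inhibition and higher numbers for weaker inhibition. Compound 1 `CC(CCO)n1cnc2c(Cl)ncnc21` gives > 50000 nM, which is a limit. Compound 2 `CCCCCC(CCO)n1cnc2c(Cl)ncnc21` gives > 50000 nM, also a limit. Compound 3 `CCCCCC(CCO)n1cnc2c(OC)ncnc21` gives > 50000 nM, again a limit. Compound 2 therefore has no numerical value, and its standing is shared by the whole set: the limit of > 50000 nM in this assay, at which 3 of the 3 values shown sit.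

Compound 4 `CCCCCCCCCC(CCO)n1cnc2c(Cl)ncnc21` differs from compound 2 by butyl in place of hydrogen on a saturated chain carbon, six bonds along the chain from an aromatic nitrogen. Among the measured compounds shown here, the closest precedent is the same exchange at a shorter reach, butyl in place of hydrogen two bonds along the chain from an aromatic nitrogen, which gives a step that the two limits leave unreadable from compound 1 to compound 2. The other measured step, methoxy in place of chloro, gives a step that the two limits leave unreadable from compound 2 to compound 3. Neither supplies a size, so the expectation is weakly founded. Any readable change in this assay could only run toward lower numbers, and another limit remains quite possible. The estimated step is an at least 1.4-fold lower number from compound 2 to compound 4 (0.15 log units; that floor lies within the scatter). For compound 4 the estimated value is 35000 nM, with an expected range of 8000 nM to 60000 nM.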

Compound 4, half-maximal inhibitory concentration: 890 nM
Beside the measured number, compound 4's estimate is 39-fold (1.59 log units) above it; measured number below the stated range.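

In this assay, among the compounds shown here, butyl in place of hydrogen on a saturated chain carbon, six bonds along the chain from an aromatic nitrogen, gives the only readable step: an at least 56-fold lower number from compound 2 to compound 4 (1.74 log units; beyond the scatter). For the compounds shown here, the same exchange two bonds along the chain and methoxy in place of chloro cannot be read, and this step therefore gives the first size for any change on the shared core. Of the compounds shown, only compound 4 carries a number rather than a limit: the limit of > 50000 nM in this assay, at which 3 of the 4 values shown sit.

Going by these compounds, it remains open whether a longer chain than that of compound 4 lowers the number further, or whether a chain shorter than that of compound 4 but longer than that of compound 2 already gives a readable value. Also open, on these data alone, is whether methoxy in place of chloro on an aromatic carbon keeps the value of compound 4, 890 nM.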